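From 3-bromophenyl to 2,5-dimethylphenyl on the sulfonamide

A few compounds are considered here, and "the series" means these few. Any claim that something is new, unique, unknown or untested is made for them only; others in the source may bear on it.

Measured in a functional assay on MCF7 cells (Homo sapiens) for antiproliferative activity, read by sulforhodamine B assay, with a stated time of 48 h; on this read-out higher numbers stand for weaker inhibition and lower numbers for stronger inhibition:
- compound 1 `CCc1ccc(NS(=O)(=O)c2ccc(N3CCNC3=O)cc2)cc1`: 810 nM
- compound 2 `O=C1NCCN1c1ccc(S(=O)(=O)Nc2ccccc2)cc1`: 470 nM
- compound 3 `O=C1NCCN1c1ccc(S(=O)(=O)Nc2cccc(Br)c2)cc1`: 100 nM

Of the three, compound 3 gives the lowest number, 100 nM, and its gaps to both others lie beyond the scatter. Compound 4 `Cc1ccc(C)c(NS(=O)(=O)c2ccc(N3CCNC3=O)cc2)c1` has 2,5-dimethylphenyl in place of 3-bromophenyl on a sulfonamide nitrogen.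

Among the measured compounds shown here, three measured steps bear on this change. Adding the bromo gave a 4.7-fold lower number from compound 2 to compound 3 (0.67 log units; beyond the scatter), and exchanging 4-ethylphenyl for 3-bromophenyl gave an 8.1-fold lower number from compound 1 to compound 3 (0.91 log units; beyond the scatter). Removing the ethyl gave only a 1.7-fold lower number from compound 1 to compound 2 (0.24 log units; within the scatter). For the measured compounds named here, compound 4 gives up the bromo, and no measured compound carries two methyl groups, so the expectation rests on these steps alone. A modest move to a higher number is expected in this assay, an estimated 3.0-fold higher number from compound 3 to compound 4 (0.48 log units; beyond the scatter). For compound 4 the estimated value is 300 nM, with an expected range of 100 nM to 900 nM.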

Compound 4, half-maximal inhibitory concentration: 48 nM
The estimate for compound 4 lay 6.3-fold (0.80 log units) above the measured number; the whole stated range lies above it.
By their numbers in this assay, from the lowest: compound 4; then compound 3; then compounds 2 and 1 (each within the scatter of the next).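

In this assay, the bromo proves not to be needed for a low number at this position: 2,5-dimethylphenyl on the sulfonamide nitrogen, which carries no halogen, goes further, with a 2.1-fold lower number from compound 3 to compound 4 (0.32 log units; beyond the scatter). The same group also improves on the unsubstituted phenyl, with a 9.8-fold lower number from compound 2 to compound 4 (0.99 log units; beyond the scatter), and on 4-ethylphenyl, with a 17-fold lower number from compound 1 to compound 4 (1.23 log units; beyond the scatter), so compound 4 stands lowest of the four, yet compound 1 goes against any idea that substituting the phenyl is enough in itself, since its step to compound 2 lies within the scatter. Nothing available accounts for the gain brought by the 2,5-dimethylphenyl group.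

The compounds shown leave open whether either methyl alone would give as low a number as the pair. They also leave open how a methoxy or an amine in the place of those methyl groups would read.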